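Working notes: aryl halogen swap, compound 2 to compound 3

A few compounds are considered here, and "the series" means these few. Any claim that something is new, unique, unknown or untested is made for them only; others in the source may bear on it.

Measured so far in a functional assay on HeLa cells (Homo sapiens) for cytotoxicity, read by MTT assay, with a stated time of 48 h; a lower number here means a stronger inhibitor, a higher number a weaker inhibitor:
Compound 1, `CCOC(=O)c1c(-c2cc3ccccc3oc2=O)nn(-c2cccc(Cl)c2)c1C(=O)OCC`: 22000 nM
Compound 2, `CCOC(=O)c1c(-c2cc3ccccc3oc2=O)nn(-c2ccc(Cl)cc2)c1C(=O)OCC`: 87000 nM

Among the measured compounds shown here, compound 2 gives the highest of the two numbers recorded in this assay; its nearest neighbour is compound 1, and the single measured step, a 4.0-fold higher number from compound 1 to compound 2 (0.60 log units; beyond the scatter), is the only comparison available.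

Compound 3, `CCOC(=O)c1c(-c2cc3ccccc3oc2=O)nn(-c2ccc(Br)cc2)c1C(=O)OCC`, has not yet been measured. It differs from compound 2 by bromo in place of chloro on an aromatic carbon. Cut one bond further out, the change reads 4-chlorophenyl to 4-bromophenyl.

For the measured compounds named here, no measured step bears directly on this change. Going by the values given here, the one recorded step moves the chloro group from one position to another on the phenyl ring and does not exchange one halogen for another, so it gives no guidance on the size or direction of a chloro to bromo swap. The numbers therefore offer no basis for a step beyond the scatter in either direction in this assay, and the expected number for compound 3 lies close to that of compound 2. The expected step is a 1.1-fold lower number from compound 2 to compound 3 (0.04 log units; within the scatter). Compound 3 is estimated at 80000 nM, with a range from 30000 nM to 200000 nM.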

Compound 3, half-maximal inhibitory concentration: 250000 nM
Compound 3: the middle estimate sits 3.1-fold (0.49 log units) below what was measured; measured number above the stated range.
By their numbers in this assay, from the lowest: compound 1; then compound 2; then compound 3.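

At the aromatic carbon para to a large group, the identity of the halogen matters in this assay: bromo in place of chloro gives a 2.9-fold higher number from compound 2 to compound 3 (0.46 log units; beyond the scatter), so the number responds to exchanging one halogen for another as well as to where the chloro group sits. With 4-bromophenyl in place of 3-chlorophenyl on the aromatic nitrogen, the series shows an 11-fold higher number from compound 1 to compound 3 (1.06 log units; beyond the scatter), the widest gap among these three compounds, and compound 1 remains the strongest inhibitor of the set. No measured data available here offer an account of either step.

Left open is how fluoro, methoxy or an amine on the same aromatic carbon would compare, and whether 3-bromophenyl would give a lower number than 4-bromophenyl, as 3-chlorophenyl does against 4-chlorophenyl. The three compounds also leave open how far these differences carry over to changes elsewhere on the shared core, such as a carboxylic acid in place of either ester group.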